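The source may hold more compounds than are shown below. What is called first, only, known or untested is meant among the compounds shown, and "the series" means these compounds.

Compound 1, `O=S(=O)(/C=C/c1ccccn1)c1cccc(Cl)c1`, gives 1430 nM. Compound 2, `O=S(=O)(/C=C/c1cccnc1Cl)c1cccc(F)c1`, gives 328 nM. Compound 3, `O=S(=O)(/C=C/c1cccnc1)c1cccc(Cl)c1`, gives 3520 nM.

Of the compounds shown here, three have been measured in an assay on U2OS cells for activation of nuclear factor erythroid 2-related factor 2 (Homo sapiens), read by beta-arrestin recruitment, with a stated time of 6 h; on this read-out lower numbers stand for an effect already at smaller amounts and higher numbers for an effect only at larger amounts of compound. Among the compounds with values here, compound 3 stands at the highest of the three numbers: compound 1 is its nearest neighbour, and the only step with a single change, a 2.5-fold higher number from compound 1 to compound 3 (0.39 log units; beyond the scatter), moved the number up on going from the pyridin-2-yl to the pyridin-3-yl compound. Compound 2 lies furthest away, with a lower number than either.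

Compound 4, `O=S(=O)(/C=C/c1cccnc1Cl)c1cccc(Cl)c1`, is the next compound, and it differs from compound 3 by chloro in place of hydrogen on an aromatic carbon. Within the data shown here, no measured step covers this change on its own: the one measured step concerns where the ring nitrogen sits, not a chloro on that ring. Compound 2 does carry the same chloro on the pyridine, yet it also differs from compound 3 at the other ring, so its value can only hint at the direction. A step toward a lower number, a 5.9-fold lower number from compound 3 to compound 4 (0.77 log units; beyond the scatter), is therefore expected, but with wide uncertainty. Compound 4 is estimated at 600 nM, within 150 nM to 2500 nM.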

Compound 4, half-maximal effective concentration: 213 nM
The estimate for compound 4 lay 2.8-fold (0.45 log units) above the measured number, within the range that was stated.
By their numbers in this assay, from the lowest: compounds 4 and 2 (each within the scatter of the next); then compound 1; then compound 3.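

In this assay, the chloro on the nitrogen-bearing ring, next to the ring nitrogen, gives a 17-fold lower number from compound 3 to compound 4 (1.22 log units; beyond the scatter) as a single change, so this position can shift the number strongly. With that chloro present, changing the group on the other ring leaves compounds that cannot be ordered, with chloro in place of fluoro giving a 1.5-fold lower number from compound 2 to compound 4 (0.19 log units; within the scatter) and so no real difference between these two halogens there. Nothing measured here explains either result.

As far as these compounds go, it remains open whether chloro is special at this position or whether a methyl, a methoxy or an amine in the same place would give a similar number. From the compounds shown here alone, it is also open whether the same chloro would have a comparable effect on the pyridin-2-yl ring of compound 1.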